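A few compounds are considered here, and "the series" means these few. Any claim that something is new, unique, unknown or untested is made for them only; others in the source may bear on it.

Compound 1 `CC(=O)OC1(CC#Cc2ccccc2)C=CC(=O)/C1=C/c1ccccc1` and compound 2 `O=C1C=CC(CC#Cc2ccccc2)(OC2CCCCO2)/C1=C/c1ccccc1` are two close relatives within this set. In a functional assay on HeLa cells (Homo sapiens) for cytotoxicity (on this read-out lower numbers stand for stronger inhibition and higher numbers for weaker inhibition), compound 1 gives 24 nM, while compound 2 gives 1100 nM. Compound 3 `O=C1CC(SCCO)/C(=C/C#Cc2ccccc2)C1C(SCCO)c1ccccc1` is built on a different arrangement of the same pieces. In this assay compound 3 reaches only > 1000000 nM, which is a limit of the assay and not a number. Compound 3 thus stands at the limit of > 1000000 nM in this assay, at which 1 of the 3 values shown sits. Compound 4 `O=C1CC(SCCO)/C(=C\C#Cc2ccccc2)C1C(SCCO)c1ccccc1` keeps the same atoms and bonds as compound 3; (the two compounds have the same atoms and bonds; at least one stereo element is drawn with a configuration in one of them and without one in the other: 1 of 4 stereo elements differ; a double bond is drawn E in compound 3 and Z in compound 4). Among the compounds with values here, no step between measured compounds is available here, so in this assay the change from compound 3 to compound 4 is expected to stay within the usual scatter, in no particular direction. Compound 4 is therefore estimated at 2000000 nM, between 300000 nM and 10000000 nM, an expected step that the limit leaves unreadable from compound 3 to compound 4, most likely again reported only as a limit.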

Compound 4, half-maximal inhibitory concentration: 1000000 nM
For compound 4 the middle estimate is 2.0-fold (0.30 log units) above the measured one; measured number inside the range.
By their numbers in this assay, from the lowest: compound 1; then compound 2; then compound 4.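

In this assay compound 3 gives > 1000000 nM, which is a limit of the assay and not a number. With a Z double bond in place of the E one, compound 4 gives 1000000 nM, so this change alone does not bring the value down to a clearly lower number. The data show a number no higher from compound 3 to compound 4 (the limit leaves the size open). The size of the step cannot be read, and the comparison carries a further caution: the fact that one of compounds 3 and 4 is drawn with a defined configuration and the other without, at the place where they differ

The compounds shown leave open whether an amine in place of the hydroxyl groups would give lower numbers in this pair.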